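The source may hold more compounds than are shown below. What is called first, only, known or untested is meant among the compounds shown, and "the series" means these compounds.

Compound 1, `Cc1cc(C)cc(NC(=O)COc2cc(C)nc3ccccc23)c1`: in a toxicity assay on HepG2 cells (Homo sapiens) for inhibition, read by CellTiter-Glo, with a stated time of 48 h (a lower number here means a stronger inhibitor, a higher number a weaker inhibitor), compound 1 gives > 100000 nM, which is a limit of the assay and not a number.
Compound 2, `Cc1cc(C)cc(NC(=O)COc2cc(C)nc3ccc(C(F)(F)F)cc23)c1`: in this assay compound 2 gives > 100000 nM, again a limit of the assay rather than a number.

Compound 2 therefore stands only at a limit in this assay, and nothing shown places it more precisely; the same holds for the other value, since (the limit of > 100000 nM in this assay, at which 2 of the 2 values shown sit). Among the measured compounds shown here, the one measured step, a step that the two limits leave unreadable from compound 1 to compound 2, cannot be read in size or direction, as both of its ends are limits.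

The next change leads to compound 3, `Cc1cc(C)cc(NC(=O)COc2cc(C)nc3ccc(OCc4ccccc4)cc23)c1`, and consists of benzyloxy in place of trifluoromethyl on an aromatic carbon. For the measured compounds named here, no measured step bears on this change with a readable size, so there is no basis for expecting a step beyond the scatter in this assay in either direction. The expectation for compound 3 is consequently that it remains near the limit where compound 2 sits, so that the step from compound 2 to compound 3 is expected to be about a number no higher from compound 2 to compound 3 (the limit leaves the size open). The estimate for compound 3 in this assay is thus 100000 nM, with a range from 30000 nM to 300000 nM.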

Compound 3, half-maximal inhibitory concentration: > 100000 nM
Compound 3 gave a limit, no number; the forecaster's own chance of this, stated with the estimate: 70%; the middle value sits exactly at the limit.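

In this assay compound 3 gives > 100000 nM, a limit of the assay and not a number. The steps among compound 1, compound 2 and compound 3 therefore cannot be read in size or direction: the limit of > 100000 nM in this assay, at which 3 of the 3 values shown sit. The compounds shown leave open whether trifluoromethyl or benzyloxy on the shared core makes any difference in this assay.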